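The source may report more compounds than this note shows. Statements on the series, on what has been measured and on what is new or still open speak of the compounds shown alone.

Measured so far in a functional assay on the whole organism (strain Sprague-Dawley) for inhibition, with Rattus norvegicus as the target, with a stated time of 10 min; on this read-out lower numbers stand for an effect already at smaller amounts and higher numbers for an effect only at larger amounts of compound:
Compound 1, `CCOc1ccc([N+](=O)[O-])cc1-c1ncc(C(=O)O)c(=O)[nH]1`: 25 mg/kg
Compound 2, `CCOc1ccc(N)cc1-c1ncc(C(=O)O)c(=O)[nH]1`: 1.2 mg/kg
Compound 3, `CCOC(=O)c1cnc(-c2cc([N+](=O)[O-])ccc2OCC)[nH]c1=O`: 5 mg/kg

Of the compounds shown here, three have been measured in this assay. Compound 1 gives 25 mg/kg and stands highest of the three. Compound 2 differs from it by one change, (amino in place of nitro on an aromatic carbon), and this change brought a 21-fold lower number from compound 1 to compound 2 (1.32 log units; beyond the scatter). Compound 3 differs from compound 1 in a different place, (ethyl in place of hydrogen on an oxygen next to a carbonyl group), and that step was a 5.0-fold lower number from compound 1 to compound 3 (0.70 log units; beyond the scatter). Between compound 2 and compound 3 no single-place step is described; their two values simply show compound 2 with the lower number.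

Compound 4, `CCOC(=O)c1cnc(-c2cc(N)ccc2OCC)[nH]c1=O`, has not yet been measured. It differs from compound 3 by amino in place of nitro on an aromatic carbon. This is the same change that was made from compound 1 to compound 2, and the surroundings of the place are described in the same words in both cases, so it is the same change on a different core; the two cores differ by ethyl in place of hydrogen on an oxygen next to a carbonyl group.

Going by the values given here, only one earlier example of this change exists, so the expectation rests on a single step. Since that step in this assay from compound 1 to compound 2 was large and beyond the scatter, a step of similar direction is expected for compound 4, estimated as a 13-fold lower number from compound 3 to compound 4 (1.10 log units; beyond the scatter). Compound 4 is thus expected to give about 0.4 mg/kg, with a plausible range from 0.1 mg/kg to 1.6 mg/kg.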

Compound 4, dose for 50% inhibition: 0.5 mg/kg
Beside the measured number, compound 4's estimate is 1.3-fold (0.10 log units) below it, within the range that was stated.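

In this assay, amino in place of nitro on the core of compound 3 again lowered the number, a 10-fold lower number from compound 3 to compound 4 (1.00 log units; beyond the scatter), and this step agrees with the earlier one on the core of compound 1: the same change on two cores in this assay, a 21-fold lower number (1.32 log units; beyond the scatter) from compound 1 to compound 2 and a 10-fold lower number (1.00 log units; beyond the scatter) from compound 3 to compound 4, 2.1-fold (0.32 log units) apart, within the scatter of two such steps. The other change, ethyl in place of hydrogen on an oxygen next to a carbonyl group, also lowered the number when carried onto the amino compound, a 2.4-fold lower number from compound 2 to compound 4 (0.38 log units; beyond the scatter), and it too agrees with its earlier step: the same change on two cores in this assay, a 5.0-fold lower number (0.70 log units; beyond the scatter) from compound 1 to compound 3 and a 2.4-fold lower number (0.38 log units; beyond the scatter) from compound 2 to compound 4, 2.1-fold (0.32 log units) apart, within the scatter of two such steps. Across these four compounds, each change therefore carried from one core to the other in the same direction and to a comparable extent, but each comparison rests on a single pair of steps in this assay, which shows neither why the number falls nor whether the same would hold on a further core.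

The compounds shown leave open whether other groups on that aromatic carbon, such as an acetamide or a methylamino group, would follow the amino compounds. They also leave open how a longer chain than ethyl on the carbonyl-linked oxygen, or an amide in its place, would behave, and whether the ethoxy group itself could be replaced by a longer chain.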